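The source may report more compounds than this note shows. Statements on the series, on what has been measured and on what is new or still open speak of the compounds shown alone.

Measured compounds in an ADME assay on L02 cells (Homo sapiens) for antiproliferative activity, read by MTT assay, with a stated time of 48 h; a higher number here means a weaker inhibitor, a lower number a stronger inhibitor:

Compound 1 `N#CC1=C(N)Oc2c(c3nc4ccccc4nc3c3ccccc23)C12C(=O)N(Cc1cnnn1-c1ccccc1Br)c1ccccc12` — in this assay compound 1 gives > 50000 nM, which is a limit of the assay and not a number.
Compound 2 `N#CC1=C(N)Oc2c(N)cc3nc4ccccc4nc3c2C12C(=O)N(Cc1cnnn1-c1ccccc1Cl)c1ccccc12` — compound 2 gives > 50000 nM, again a limit rather than a number.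
Compound 3 `N#CC1=C(N)Oc2c(N)cc3nc4ccccc4nc3c2C12C(=O)N(Cc1cnnn1-c1ccc([N+](=O)[O-])cc1)c1ccccc12` — compound 3 gives > 50000 nM, likewise only a limit.

Compound 3 therefore stands where every value shown stands, at the limit of > 50000 nM in this assay, at which 3 of the 3 values shown sit; none of the three compounds has a numerical reading in this assay.

Compound 4 `N#CC1=C(N)Oc2c(N)cc3nc4ccccc4nc3c2C12C(=O)N(Cc1cnnn1-c1ccc(Cl)cc1[N+](=O)[O-])c1ccccc12` differs from compound 3 in one place: 4-chloro-2-nitrophenyl in place of 4-nitrophenyl on an aromatic nitrogen. Going by the values given here, the only measured step that touches this kind of change is a step that the two limits leave unreadable from compound 2 to compound 3, which also swaps the group on that same aromatic nitrogen; its size cannot be read, as both of its compounds sit at the limit of > 50000 nM in this assay, at which 3 of the 3 values shown sit. Among the compounds with values here, no measured step gives any size or direction to expect in this assay, and nothing points to compound 4 escaping the limit.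

The step from compound 3 to compound 4 is expected to be a step that the limit leaves unreadable from compound 3 to compound 4, within the scatter. Compound 4 is estimated at 60000 nM, with a range from 20000 nM to 200000 nM, most likely reported again as a limit only.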

Compound 4, half-maximal inhibitory concentration: > 50000 nM
Compound 4 was reported as a limit (the forecaster's own chance of this, stated with the estimate: 85%); the middle value lies beyond the limit too.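

No size can be read for the changes from compound 3 to compound 4 or from compound 2 to compound 4, because compound 2, compound 3 and compound 4 give only a limit in this assay: the limit of > 50000 nM in this assay, at which 4 of the 4 values shown sit.

The compounds shown leave open whether any change to the group on the aromatic nitrogen would give a numerical reading in this assay.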